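A few compounds are considered here, and "the series" means these few. Any claim that something is new, unique, unknown or untested is made for them only; others in the source may bear on it.

Compound 1, `CS(=O)(=O)C1CCN(C(=O)CCSc2nc3cc(Cl)ccc3o2)C1`: 2.1 mL/min/g
Compound 2, `O=C(CCSc1nc2cc(F)ccc2o1)N1CCCC1`: 115 mL/min/g
Compound 3, `O=C(CCSc1nc2ncccc2o1)N1CCCC1`: 18.6 mL/min/g

In an ADME assay on microsomes from liver (Mus musculus) for metabolic stability, read by LC-MS, using NADPH, with a stated time of 45 min, tested at 0.5 uM (on this read-out higher numbers stand for fast clearance and lower numbers for slow clearance), compound 1 gives the lowest of these three numbers; compound 3 comes nearest, and compound 2 lies furthest away, both gaps beyond the scatter. Compound 4, `CC1CCN(C(=O)CCSc2nc3cc(Cl)ccc3o2)C1`, is not yet measured. It differs from compound 1 in one place: methyl in place of methylsulfonyl on a saturated ring carbon. Within the data shown here, no measured pair separated by exactly this change exists, so the expectation rests on the other compounds. Compound 2 and compound 3 carry no group on that saturated ring carbon and both clear faster than compound 1. An upward step, beyond the scatter, is therefore expected a 14-fold higher number from compound 1 to compound 4 (1.15 log units; beyond the scatter). Compound 4 is estimated at 30 mL/min/g, within a range from 8 mL/min/g to 110 mL/min/g.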

Compound 4, intrinsic clearance in a liver preparation (reported as CLH), per the amount of preparation that the assay uses: 90.7 mL/min/g
Compound 4: the middle estimate sits 3.0-fold (0.48 log units) below what was measured; low and high end bracket the measured number.
By their numbers in this assay, from the lowest: compound 1; then compound 3; then compounds 4 and 2 (each within the scatter of the next).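

In this assay, this saturated ring carbon, two ring bonds from the ring nitrogen, proves highly sensitive: methyl in place of methylsulfonyl gives a 43-fold higher number from compound 1 to compound 4 (1.64 log units; beyond the scatter), with the rest of the structure unchanged. This direct comparison links the low number of compound 1 to methylsulfonyl rather than to the shared core. No available evidence explains the size of this step.

Going by these compounds, how an amine or a carboxylic acid on this ring carbon would compare remains open, as does whether other sulfur-containing groups would keep the number low.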